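Amide substituent changes in the urotensin-2 receptor series

A few compounds are considered here, and "the series" means these few. Any claim that something is new, unique, unknown or untested is made for them only; others in the source may bear on it.

Compound 1 `CN(C)CCCOc1ccc(CN2CC[C@H](NC(=O)c3cc(Cl)cc(Cl)c3)C2)cc1` carries a 3,5-dichlorophenyl group on the amide carbonyl. In an assay on HEK293 cells for binding affinity to Urotensin-2 receptor (Homo sapiens), read by radioligand binding (a lower number here means a stronger inhibitor, a higher number a weaker inhibitor), compound 1 gives 2000 nM. Compound 2 `CN(C)CCCOc1ccc(CN2CC[C@H](NC(=O)c3ccc4ccccc4c3)C2)cc1` places naphthalen-2-yl on the same carbonyl carbon. In this assay compound 2 is known only as a limit, < 10000 nM, so its value is not a number. For the measured compounds named here, the step that the limit leaves unreadable from compound 1 to compound 2 therefore cannot be read in size or direction; the only evidence on the measured steps is the limit of < 10000 nM in this assay, at which 1 of the 2 values shown sits.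

Compound 3 `CC(=O)N[C@@H](CC(C)C)C(=O)N[C@H]1CCN(Cc2ccc(OCCCN(C)C)cc2)C1` is not yet measured. It differs from compound 2 in the group on the carbonyl carbon: 1-acetamido-3-methylbutyl in place of naphthalen-2-yl on a carbonyl carbon. Going by the values given here, since the one measured step is unreadable and no other pair shares this change, no measured step bears on the expected size of this step. Compound 3 is expected to sit near 3000 nM, within 300 nM to 30000 nM, so the step that the limit leaves unreadable from compound 2 to compound 3 is an estimate without directional support from the measured data, and a limit instead of a number remains quite possible for compound 3.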

Compound 3, inhibition constant: 2510 nM
For compound 3 the middle estimate is 1.2-fold (0.08 log units) above the measured one; measured number inside the range.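

Working notes on the group on the carbonyl carbon: in this assay, 1-acetamido-3-methylbutyl in place of 3,5-dichlorophenyl gives a 1.3-fold higher number from compound 1 to compound 3 (0.10 log units; within the scatter). For the compounds shown here, this is the first readable step at this position, and it shows that a group with no ring, carrying a hydrogen-bond donor and acceptor, gives a value within the scatter of the value for an aromatic group, so an aromatic ring on this carbonyl carbon is not required at this level in this pair. Compound 2 remains a limit and not a number, so neither step involving it can be read, and the comparison of naphthalen-2-yl with the other two groups stays closed: the limit of < 10000 nM in this assay, at which 1 of the 3 values shown sits.

Since the acetamido part, the 3-methylbutyl chain and the defined stereocentre enter together, the compounds shown do not separate their contributions to the value of compound 3. A free amine in place of the acetamido part, a carboxylic acid on the chain, or the opposite configuration at the new stereocentre would test whether this position tolerates further change.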